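Methoxy added to the aryl ring: ester series note

This account rests on a few compounds, and the source may have more. Where it says the series, first, only, none or still open, it means among the compounds named here.

Compound 1 `CCOc1ccccc1-c1ncc(C(=O)O)c(=O)[nH]1` in a functional assay on the whole organism (strain Sprague-Dawley) for inhibition, with Rattus norvegicus as the target, with a stated time of 10 min (a lower number here means that less compound is needed, a higher number that more compound is needed for the effect), gives 0.5 mg/kg.
Compound 2 `CCOc1ccc(OC)cc1-c1ncc(C(=O)O)c(=O)[nH]1` in this assay gives 0.2 mg/kg.
Compound 3 `CCOC(=O)c1cnc(-c2ccc(OC)cc2)[nH]c1=O` in this assay gives 30 mg/kg.

Compound 2 differs from compound 1 by methoxy in place of hydrogen on an aromatic carbon, and this gave a 2.5-fold lower number from compound 1 to compound 2 (0.40 log units; beyond the scatter). Compound 3 has the highest number of the three; how its core differs from the core of compound 1 is not broken down here.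

Compound 4 `CCOC(=O)c1cnc(-c2ccc(OC)cc2OC)[nH]c1=O` differs from compound 3 by methoxy in place of hydrogen on an aromatic carbon. This is the same kind of change as from compound 1 to compound 2, but the place is not the same: here the methoxy enters ortho to a large group and meta to a methoxy group, whereas in compound 2 it entered meta to a large group and para to an ethoxy group. The step from compound 3 to compound 4 is expected to be a 3.0-fold lower number from compound 3 to compound 4 (0.48 log units; beyond the scatter), a somewhat larger gain than a 2.5-fold lower number from compound 1 to compound 2 (0.40 log units; beyond the scatter), resting only on that one earlier step and held with wide uncertainty. Compound 4 is therefore estimated at 10 mg/kg, between 3 mg/kg and 40 mg/kg.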

Compound 4, dose for 50% inhibition: 5 mg/kg
Compound 4: the middle estimate sits 2.0-fold (0.30 log units) above what was measured; the range from low to high includes it.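

In this assay the new step is a 6.0-fold lower number from compound 3 to compound 4 (0.78 log units; beyond the scatter), in the same direction as the earlier methoxy step on the other core. The two steps agree in size: the same change on two cores in this assay, a 2.5-fold lower number (0.40 log units; beyond the scatter) from compound 1 to compound 2 and a 6.0-fold lower number (0.78 log units; beyond the scatter) from compound 3 to compound 4, 2.4-fold (0.38 log units) apart, within the scatter of two such steps. This supports carrying the change between these two cores, but it rests on one pair per core, with the methoxy at a different place on the aromatic ring in each pair, so the effects of place and core are not separated and no general rule follows.

Open, as far as these compounds go, is whether an amine or a chlorine at the same place would follow methoxy. Also open, from the compounds shown here alone, is whether the step would hold with an amide in place of the ester.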